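A few compounds are considered here, and "the series" means these few. Any claim that something is new, unique, unknown or untested is made for them only; others in the source may bear on it.

Two compounds give numbers in an assay for inhibition of Fatty-acid amide hydrolase 1 (Rattus norvegicus); a higher number here means a weaker inhibitor, a lower number a stronger inhibitor. Compound 1 `COC(=O)c1cc(-c2cnc(C(=O)CCc3ccc(-c4ccccc4)cc3)o2)ccn1` gives 1.5 nM in this assay. Compound 2 `CN(C)C(=O)c1cnc(C(=O)CCc2ccc(COc3ccccc3)cc2)o1` gives 6.7 nM in this assay. Compound 1 thus stands at the lowest of the two numbers; the nearest is compound 2, whose number is higher by a margin beyond the scatter, so compound 1 is the stronger inhibitor of the pair.

Compound 3 `O=C(CCc1ccc(-c2ccccc2)cc1)c1ncc(C(=O)C(F)(F)F)o1` has not yet been measured in this assay. It differs from compound 1 in one place: (trifluoromethyl)carbonyl in place of 2-(methoxycarbonyl)pyridin-4-yl on an aromatic carbon. The whole shared core and the long side chain carrying the biphenyl are kept; only the group on the five-membered aromatic ring is exchanged, a six-membered aromatic ring with an ester leaving and a small fluorinated group entering.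

Among the compounds with values here, no step between measured compounds matches this change. The drop in the ring with its ester is expected to cost some potency, since compound 2, which carries a smaller group on the same ring position, gives 6.7 nM. The step from compound 1 to compound 3 is estimated at a 6.7-fold higher number from compound 1 to compound 3 (0.82 log units; beyond the scatter), towards a weaker inhibitor. Compound 3 is therefore expected to give about 10 nM in this assay, within a range from 2 nM to 50 nM.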

Compound 3, inhibition constant: 8 nM
The estimate for compound 3 lay 1.3-fold (0.10 log units) above the measured number; the measured number falls inside the stated range.
By their numbers in this assay, from the lowest: compound 1; then compounds 2 and 3 (each within the scatter of the next).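

Within the data shown here, on the aromatic carbon next to the ring oxygen, replacing 2-(methoxycarbonyl)pyridin-4-yl with (trifluoromethyl)carbonyl gives a 5.3-fold higher number from compound 1 to compound 3 (0.73 log units; beyond the scatter) in this assay, the first single-place change at this position that can be read. The six-membered aromatic ring and its ester are therefore not required for activity in the low range of this assay, since compound 3, with a much smaller group and no ring there, still gives 8 nM, although the step runs towards a weaker inhibitor and lies beyond the scatter. Nothing in the available data accounts for the size of this step.

The compounds shown leave open which part of the departing group carries the difference, the six-membered aromatic ring or its methoxycarbonyl group; a plain pyridin-4-yl, or the same ring bearing a carboxylic acid in place of the ester, would separate the two. They also leave open how a nitrile or an ethyl ester on this same aromatic carbon would compare with the (trifluoromethyl)carbonyl group of compound 3.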